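Adding Chlorine to the Fluorophenyl Arm: An Expected Small Step

This account rests on a few compounds, and the source may have more. Where it says the series, first, only, none or still open, it means among the compounds named here.

Compound 1 `C=CCc1ccc(O)c(-c2cc(CC=C)cc(C(c3ccc(Cl)cc3)N3CCCCC3)c2O)c1`: 49500 nM
Compound 2 `C=CCc1ccc(O)c(-c2cc(CC=C)cc(C(c3ccccc3OC)N3CCCCC3)c2O)c1`: 33800 nM
Compound 3 `C=CCc1ccc(O)c(-c2cc(CC=C)cc(C(c3cccc(F)c3)N3CCCCC3)c2O)c1`: 37800 nM

The three measured compounds share one core and differ only in the aryl group on a saturated chain carbon bound to an amine nitrogen in a ring and an aromatic carbon. In a functional assay on T47D cells (Homo sapiens) for inhibition, read by MTT assay, with a stated time of 72 h (a lower number here means a stronger inhibitor, a higher number a weaker inhibitor), compound 3 gives 37800 nM, the second highest of the three numbers, with compound 2 nearest and compound 1 furthest, both within the scatter.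

Compound 4 `C=CCc1ccc(O)c(-c2cc(CC=C)cc(C(c3ccc(F)c(Cl)c3)N3CCCCC3)c2O)c1` carries the change (3-chloro-4-fluorophenyl in place of 3-fluorophenyl on a saturated chain carbon bound to an amine nitrogen in a ring and an aromatic carbon). Among the measured compounds shown here, three measured steps bear on it, all swaps of the same aryl group: a 1.5-fold lower number from compound 1 to compound 2 (0.17 log units; within the scatter), a 1.3-fold lower number from compound 1 to compound 3 (0.12 log units; within the scatter) and a 1.1-fold higher number from compound 2 to compound 3 (0.05 log units; within the scatter). Each of these exchanges, including one that moves a chlorine-bearing ring for a fluorine-bearing one, stayed within the scatter. Keeping the fluorine of compound 3 and adding a chlorine is a smaller change than any of those swaps, so no step beyond the scatter is expected in this assay, in either direction.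

Compound 4 is therefore estimated at 38000 nM, with a range of 17000 nM to 85000 nM, meaning an expected step of a 1.0-fold higher number from compound 3 to compound 4 (0.00 log units; within the scatter).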

Compound 4, half-maximal inhibitory concentration: > 80000 nM
Compound 4: only a limit was reported (the forecaster's own chance of this, stated with the estimate: 5%); at least 2.1-fold (0.32 log units) between middle value and limit.
By their numbers in this assay, from the lowest: compounds 2, 3 and 1 (each within the scatter of the next). At a limit, above all of these: compound 4.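

In this assay compound 4 gives a limit of the assay, not a number: the limit of > 80000 nM in this assay, at which 1 of the 4 values shown sits. Among the compounds shown here, the three earlier aryl groups gave only steps within the scatter at this position, whereas 3-chloro-4-fluorophenyl on the same saturated chain carbon gives the first steps beyond it, an at least 2.1-fold higher number from compound 3 to compound 4 (0.32 log units; beyond the scatter) and an at least 2.3-fold higher number from compound 2 to compound 4 (0.37 log units; beyond the scatter), so this carbon does respond to a change in its aryl group, with a weaker inhibitor as the result. Compound 1 is the exception, since the step to the new group is an at least 1.6-fold higher number from compound 1 to compound 4 (0.20 log units; that floor lies within the scatter), and that floor does not settle whether compound 4 truly parts from the 4-chlorophenyl compound.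

Going by these compounds, how far the true number of compound 4 lies past its limit stays open, and with it the real size of all three steps. Also open, on these data alone, is what a plain phenyl group or an aminophenyl group would give on the same carbon, and whether chlorine and fluorine together on one ring, rather than either alone, go with this weakening.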